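Widening a Small Ring on a Channel Blocker Core

The compounds below may be only part of what the source reports. "The series", "measured", "known", "first", "only" and "open" are said of these compounds alone.

Compound 2 `FC(F)(F)c1ccc(Nc2nc(N3CCC3)nc3sc(Nc4c(Cl)cccc4Cl)nc23)cc1` is the weaker of the two measured compounds in a functional assay on HEK293 cells for antagonist activity at transient receptor potential cation channel subfamily V member 1 (Homo sapiens), read by calcium flux; on this read-out higher numbers stand for weaker inhibition and lower numbers for stronger inhibition: compound 2 gives 59 nM. Its parent, compound 1 `FC(F)(F)c1ccc(Nc2ncnc3sc(Nc4c(Cl)cccc4Cl)nc23)cc1`, carries only hydrogen at the same aromatic carbon; in this assay compound 1 gives 12 nM. For the measured compounds named here, the one measured step, a 4.9-fold higher number from compound 1 to compound 2 (0.69 log units; beyond the scatter), shows that attaching azetidin-1-yl costs some activity. Compound 2 thus stands at the high end of the two numbers.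

Compound 3 `FC(F)(F)c1ccc(Nc2nc(N3CCCC3)nc3sc(Nc4c(Cl)cccc4Cl)nc23)cc1` differs from compound 2 by pyrrolidin-1-yl in place of azetidin-1-yl on an aromatic carbon. Going by the values given here, no measured step follows a change from one small ring to another at this site; the step of a 4.9-fold higher number from compound 1 to compound 2 (0.69 log units; beyond the scatter) only shows that a ring of this kind is tolerated with modest loss. The expected outcome for compound 3 is therefore a step of roughly nothing beyond the scatter, a 1.2-fold higher number from compound 2 to compound 3 (0.07 log units; within the scatter). Compound 3 is estimated at 70 nM in this assay, expected to fall from 25 nM to 200 nM.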

Compound 3, half-maximal inhibitory concentration: 12 nM
For compound 3 the middle estimate is 5.8-fold (0.77 log units) above the measured one, outside the stated range (below it).
By their numbers in this assay, from the lowest: compounds 1 and 3 (each within the scatter of the next); then compound 2.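

In this assay, exchanging azetidin-1-yl for pyrrolidin-1-yl on this aromatic carbon gives a 4.9-fold lower number from compound 2 to compound 3 (0.69 log units; beyond the scatter), so the four-membered and five-membered rings are not interchangeable at this position. The step of no change at the digits printed from compound 1 to compound 3 (within the scatter) adds a second point: this carbon can carry pyrrolidin-1-yl with the read-out staying within the scatter of the hydrogen parent, so the cost seen with azetidin-1-yl does not apply to every ring placed here. Nothing available explains why the two rings differ.

The compounds shown leave open how piperidin-1-yl, morpholin-4-yl or an open-chain amine such as dimethylamino would read at this carbon. For the compounds shown here, with only two ring sizes in hand, they also cannot say whether the read-out follows any regular course as the ring grows.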